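The source may hold more compounds than are shown below. What is called first, only, known or untested is meant among the compounds shown, and "the series" means these compounds.

The two measured compounds share one core and differ only in the aryl group that sits on a carbon with a double bond to nitrogen. Compound 1, `Cc1nc(N(C)C(=O)NC(=O)c2c(F)cccc2F)sc1C(=O)N/N=C/c1ccc(Cl)cc1`, carries a 4-chlorophenyl group there. In a functional assay on HepG2 cells (Homo sapiens) for inhibition, read by MTT assay, with a stated time of 72 h (on this read-out higher numbers stand for weaker inhibition and lower numbers for stronger inhibition), compound 1 gives only a limit of the assay, > 100 ug/mL. Among the compounds with values here, compound 2, `Cc1nc(N(C)C(=O)NC(=O)c2c(F)cccc2F)sc1C(=O)N/N=C/c1cccc(C(F)(F)F)c1`, carries a 3-(trifluoromethyl)phenyl group on that carbon, and in this assay compound 2 gives 31.6 ug/mL, the only numerical value among the measured compounds. Within the data shown here, the single measured step, an at least 3.1-fold lower number from compound 1 to compound 2 (0.50 log units; beyond the scatter), therefore marks a move away from the limit of > 100 ug/mL in this assay, at which 1 of the 2 values shown sits. Compound 3, `Cc1nc(N(C)C(=O)NC(=O)c2c(F)cccc2F)sc1C(=O)N/N=C/c1ccc(F)cc1`, introduces the change (4-fluorophenyl in place of 3-(trifluoromethyl)phenyl on a carbon with a double bond to nitrogen). This change undoes the measured step in part, since a halogen-bearing phenyl again takes the place of the trifluoromethyl-bearing one. Among the measured compounds shown here, because the only measured step, an at least 3.1-fold lower number from compound 1 to compound 2 (0.50 log units; beyond the scatter), ran toward stronger inhibition when the 4-chlorophenyl group left, the return of a halogen-bearing phenyl in compound 3 is expected to weaken inhibition, with an expected step of a 2.5-fold higher number from compound 2 to compound 3 (0.40 log units; beyond the scatter). Compound 3 in this assay is thus estimated at 80 ug/mL, within 30 ug/mL to 200 ug/mL.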

Compound 3, half-maximal inhibitory concentration: > 100 ug/mL
Compound 3: no number, only a limit; the forecaster's own chance of this, stated with the estimate: 45%; middle value at least 1.2-fold (0.09 log units) away from the limit.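

Going from 3-(trifluoromethyl)phenyl to 4-fluorophenyl on a carbon with a double bond to nitrogen gives, in this assay, an at least 3.1-fold higher number from compound 2 to compound 3 (0.50 log units; beyond the scatter). The measured number of compound 2 therefore no longer rests on a single comparison with 4-chlorophenyl, since two different halogen-bearing phenyl groups on this carbon now give only a limit, and the values gather there: the limit of > 100 ug/mL in this assay, at which 2 of the 3 values shown sit. The step from compound 1 to compound 3, fluoro in place of chloro, cannot be read, as both results are limits, so these two halogens cannot be ranked.

Compound 2 differs from compound 1 and compound 3 both in the kind of group on the phenyl ring and in where that group sits, so these compounds cannot tell whether the trifluoromethyl group itself or its place on the ring matters. A 4-(trifluoromethyl)phenyl or a 3-fluorophenyl group on the same carbon would separate those two questions, while a phenyl ring carrying a carboxylic acid or an amine would test quite different groups at this position.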